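A few compounds are considered here, and "the series" means these few. Any claim that something is new, unique, unknown or untested is made for them only; others in the source may bear on it.

Measured compounds in an in vitro assay on SH-SY5Y cells for displacement of a labelled ligand from Neuronal acetylcholine receptor; alpha3/beta4 (Homo sapiens); on this read-out lower numbers stand for stronger inhibition and higher numbers for weaker inhibition:
- compound 1, `Clc1ccc(C2=CC3CNCC(C2)C3)cn1`: 6.2 nM
- compound 2, `FC(F)(F)c1cncc(C2=CC3CNCC(C2)C3)c1`: 79 nM

Among the measured compounds shown here, compound 2 holds the highest number of the two measured so far in this assay. Its nearest neighbour is compound 1, whose number in this assay, 6.2 nM against 79 nM for compound 2, is lower by an amount that lies well beyond the scatter. For the measured compounds named here, the two differ in more than one place, so no single step between them is set down; the pair shows only that a substituent change on the shared core can shift this read-out by a large margin.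

Compound 3, `COc1cncc(C2=CC3CNCC(C2)C3)c1`, has not yet been measured in this assay. It differs from compound 2 by methoxy in place of trifluoromethyl on an aromatic carbon. Going by the values given here, no measured pair isolates this exchange, so the expected size of the step cannot be read from a precedent. A modest move toward a lower number is expected, of a size that may still fall within the scatter: the step from compound 2 to compound 3 is estimated as a 2.0-fold lower number from compound 2 to compound 3 (0.30 log units; within the scatter). Compound 3 is thus expected to give 40 nM in this assay, estimated within 10 nM to 160 nM.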

Compound 3, inhibition constant: 14.3 nM
Estimate against measurement, compound 3: 2.8-fold (0.45 log units) above, within the range that was stated.
By their numbers in this assay, from the lowest: compound 1; then compound 3; then compound 2.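

In this assay, among the compounds shown here, methoxy in place of trifluoromethyl on this aromatic carbon, two atoms from the ring nitrogen, gives a 5.5-fold lower number from compound 2 to compound 3 (0.74 log units; beyond the scatter), the first step that isolates a change in one place. The position is therefore sensitive to the group it carries, which the earlier pair could not show, and the entering methoxy has fewer heavy atoms than trifluoromethyl and brings a hydrogen-bond acceptor that trifluoromethyl lacks. Nothing measured here accounts for the size of this step, which stands as an observation only.

As far as these compounds go, it remains open whether the step follows the oxygen atom or the smaller group, a question that a methyl, a hydroxyl or an ethoxy group on the same aromatic carbon would help to settle. From the compounds shown here alone, compound 1 differs from compound 2 and compound 3 in more than one place, so it is also open whether this exchange would give a step of similar size on a ring that carries chlorine.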